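The compounds below may be only part of what the source reports. "The series", "measured", "known", "first", "only" and "open" are said of these compounds alone.

Compound 3, with the structure `COc1cccc(CCCNC(C)=O)c1`, gives 63 nM in an assay for binding affinity to melatonin receptor (Gallus gallus) (on this read-out lower numbers stand for stronger inhibition and higher numbers for weaker inhibition), the lowest of the three numbers at hand. Compound 2, built as `CCCC(=O)NCCCc1ccccc1OC`, gives 442 nM in this assay, a gap beyond the scatter; compound 1, with the structure `CCC(=O)NCc1cccc(OC)c1`, gives 22000 nM in this assay, the furthest away. Compound 2 and compound 3 differ in more than one place, so their two values only show what they show.

Compound 4, the structure `CCCC(=O)NCCCc1cccc(OC)c1`, is not yet measured. It arises from compound 3 by the change (ethyl in place of hydrogen on a saturated chain carbon bound to a carbonyl carbon), that is, ethyl in place of hydrogen on a saturated chain carbon bound to a carbonyl carbon. Going by the values given here, no single-place step of this kind stands among the measured compounds, so the expectation rests on compound 3 alone and on the general closeness of compound 2, which also carries the longer acyl chain and gives 442 nM in this assay. The step from compound 3 to compound 4 is expected to be small, a 1.2-fold higher number from compound 3 to compound 4 (0.08 log units; within the scatter), in no firm direction beyond the scatter. Compound 4 is accordingly estimated at 75 nM in this assay, within a range from 20 nM to 280 nM.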

Compound 4, inhibition constant: 5.5 nM
Compound 4: the middle estimate sits 14-fold (1.13 log units) above what was measured; measured number below the stated range.
By their numbers in this assay, from the lowest: compound 4; then compound 3; then compound 2; then compound 1.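

Ethyl in place of hydrogen on a saturated chain carbon bound to a carbonyl carbon gives an 11-fold lower number from compound 3 to compound 4 (1.06 log units; beyond the scatter) in this assay. This is the first single-place step among these compounds, and it shows that this position is sensitive: the change from acetyl to propylcarbonyl moves the number well past the usual scatter, although it adds only 2 heavy atoms and no hydrogen-bond donors or acceptors. Nothing at hand accounts for the size of this step.

From the compounds shown here alone, because this is a single step, it gives no trend along the acyl chain, and whether a longer chain such as butyl or pentyl would lower the number further or reverse the gain stays open. Also open, going by these compounds, is how a branched isopropyl group, a cyclopropyl ring or a terminal amine would fare at this place.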